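From Aryl Ether to Direct Phenyl in an M5 Series

The source may report more compounds than this note shows. Statements on the series, on what has been measured and on what is new or still open speak of the compounds shown alone.

For the measured compounds named here, compound 2 `O=C1C(=O)N(Cc2ccc(Oc3cccc(F)n3)cc2)c2ccc(OC(F)(F)F)cc21` gives 1500 nM in a functional assay on CHO cells for positive allosteric modulation of muscarinic acetylcholine receptor M5 (Homo sapiens), read by FLIPR and calcium flux, with a stated time of 1 h (on this read-out lower numbers stand for an effect already at smaller amounts and higher numbers for an effect only at larger amounts of compound), the lowest of the two numbers measured so far. Going by the values given here, its only neighbour, compound 1 `O=C1C(=O)N(Cc2ccc(Oc3ccccn3)cc2)c2ccc(OC(F)(F)F)cc21`, gives 3200 nM in this assay, and the single measured step, a 2.1-fold lower number from compound 1 to compound 2 (0.33 log units; beyond the scatter), is the whole of the experience in this set. Compound 3 `O=C1C(=O)N(Cc2ccc(-c3ccccc3)cc2)c2ccc(OC(F)(F)F)cc21` is not yet measured; it differs from compound 2 by phenyl in place of (6-fluoropyridin-2-yl)oxy on an aromatic carbon. Among the compounds with values here, the one measured step concerns a fluorine placed on the (6-fluoropyridin-2-yl)oxy group, and it bears only loosely on the removal of that whole group, oxygen included, in favour of phenyl; no measured pair shows a phenyl bound directly to the ring in place of the oxygen-linked group. The step from compound 1 to compound 2 was modest, and the present change is larger in kind, so no direction can be read from the data. Compound 3 is therefore estimated at 3000 nM, with a range from 700 nM to 13000 nM. This corresponds to an expected step of a 2.0-fold higher number from compound 2 to compound 3 (0.30 log units; within the scatter).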

Compound 3, half-maximal effective concentration: 1600 nM
Estimate against measurement, compound 3: 1.9-fold (0.27 log units) above; the range from low to high includes it.
By their numbers in this assay, from the lowest: compounds 2, 3 and 1 (each within the scatter of the next, the first and the last beyond it).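

In this assay, setting phenyl directly on the aromatic carbon para to a large group in place of (6-fluoropyridin-2-yl)oxy gives a 1.1-fold higher number from compound 2 to compound 3 (0.03 log units; within the scatter) and so opens no measurable gap between the two groups. Set against the (pyridin-2-yl)oxy group, the same phenyl gives a 2.0-fold lower number from compound 1 to compound 3 (0.30 log units; within the scatter) and is likewise not told apart, although compound 1 and compound 2 themselves lie beyond the scatter of each other. For the compounds shown here, this is the first sign that this position tolerates a group of carbon only: the two hydrogen-bond acceptors of the (6-fluoropyridin-2-yl)oxy group are absent from phenyl, and compound 3 still reads in the same range as compound 2, so neither the linking oxygen nor the ring nitrogen is needed for a response at this level.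

Still open, on these data alone, is how this position would answer to a fluoro-substituted phenyl, a pyridine ring bound directly without the oxygen, an amine or a carboxylic acid. Nothing at hand accounts for why the oxygen-linked and the direct groups read alike in this series.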